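This account rests on a few compounds, and the source may have more. Where it says the series, first, only, none or still open, it means among the compounds named here.

For the measured compounds named here, compound 1 `COc1cc(N)c(Cl)cc1NC(=O)C1CCN(CC2CCCCC2)CC1` gives 2.9 mg/kg in a functional assay on the whole organism for antagonist activity, with Mus musculus as the target (on this read-out lower numbers stand for an effect already at smaller amounts and higher numbers for an effect only at larger amounts of compound), the highest of the two numbers so far; compound 2 `COc1cc(N)c(Cl)cc1NC(=O)C1CCN(Cc2cccc(C)c2)CC1` gives 2.4 mg/kg, and the step of a 1.2-fold lower number from compound 1 to compound 2 (0.08 log units; within the scatter) sits within the scatter. Compound 3 `CCCCCCN1CCC(C(=O)Nc2cc(Cl)c(N)cc2OC)CC1` differs from compound 1 by pentyl in place of cyclohexyl on a saturated chain carbon bound to an amine nitrogen in a ring. Going by the values given here, the only step touching the same place, the one from compound 1 to compound 2, brought no change beyond the scatter, so for compound 3 a step of about a 1.0-fold higher number from compound 1 to compound 3 (0.01 log units; within the scatter) in this assay is expected, none beyond the scatter. Compound 3 is therefore estimated at 3 mg/kg, between 1.2 mg/kg and 7.5 mg/kg.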

Compound 3, dose for half-maximal effect: > 10 mg/kg
Compound 3 ended at the assay's limit; the forecaster's own chance of this, stated with the estimate: 5%; middle value at least 3.3-fold (0.52 log units) away from the limit.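

Pentyl in place of cyclohexyl at this position gives an at least 3.4-fold higher number from compound 1 to compound 3 (0.53 log units; beyond the scatter), and pentyl in place of 3-methylphenyl gives an at least 4.1-fold higher number from compound 2 to compound 3 (0.61 log units; beyond the scatter). The group here is therefore not freely exchangeable in this assay: among these three compounds, the two with a ring on the saturated chain carbon keep an effect at low doses and the open chain does not, with none going against this. The reading for compound 3 is a limit, not a number: the limit of > 10 mg/kg in this assay, at which 1 of the 3 values shown sits.

From the compounds shown here alone, the true size of both steps stays open. Also open, going by these compounds, is whether a longer chain, such as octyl, or a branched chain, such as isobutyl, would behave like pentyl or like the ring groups.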